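The compounds below may be only part of what the source reports. "The series", "measured", "known", "first", "only" and "open" are said of these compounds alone.

Working notes on the series. Among the compounds with values here, compound 3 `CNC(=O)N1CCCc2ccc(NC(=O)c3ccc(-c4ccncc4)cc3)cc21` gives 37.6% in a functional assay on MV4-11 cells (Homo sapiens) for antiproliferative activity, with a stated time of 6 days, tested at 1.56 uM (a lower number here means a weaker effect, a higher number a stronger effect of the compound at the concentration tested), the second highest of the three numbers known; compound 1 `CNC(=O)N1CCCc2ccc(NC(=O)c3ccc(-c4ccn(C)n4)cc3)cc21` gives 72.2% and compound 2 `CNC(=O)N1CCCc2ccc(NC(=O)c3ccc(-c4ccn(C(C)=O)n4)cc3)cc21` gives 35.8%. Compound 4 `CNC(=O)N1CCCc2ccc(NC(=O)c3ccc(-c4ccccn4)cc3)cc21` is not yet measured. It differs from compound 3 by pyridin-2-yl in place of pyridin-4-yl on an aromatic carbon. Steps at the same carbon are known: a number 34.6 percentage points lower from compound 1 to compound 3 (beyond the scatter) and a number 1.8 percentage points higher from compound 2 to compound 3 (within the scatter). Within the data shown here, no step between two pyridyl groups is known, and the two measured changes at that position were either large or within scatter. A step of no more than modest size is therefore expected, direction uncertain, as a number 2.4 percentage points higher from compound 3 to compound 4 (within the scatter). Compound 4 is estimated at 40%, with a range from 15% to 68%.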

Compound 4, a percentage reported as inhibition, at one concentration (the size of the read-out at that concentration, not a potency): 32%
For compound 4 the middle estimate is 8 percentage points above the measured one, within the range that was stated.
By their numbers in this assay, from the lowest: compounds 4, 2 and 3 (each within the scatter of the next); then compound 1.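

The pyridin-2-yl and pyridin-4-yl groups cannot be told apart in this assay (a number 5.6 percentage points lower from compound 3 to compound 4 (within the scatter)), and pyridin-2-yl is likewise not separated from 1-acetyl-1H-pyrazol-3-yl (a number 3.8 percentage points lower from compound 2 to compound 4 (within the scatter)). Only 1-methyl-1H-pyrazol-3-yl stands apart (a number 40.2 percentage points lower from compound 1 to compound 4 (beyond the scatter)), so the position of the ring nitrogen in these two pyridyl groups does not close the gap to compound 1. Nothing available bears on the reason for this.

Open, going by these compounds, is how pyridin-3-yl compares, and how an ethyl group or a longer chain would compare with the methyl on the aromatic nitrogen of compound 1.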